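A few compounds are considered here, and "the series" means these few. Any claim that something is new, unique, unknown or untested is made for them only; others in the source may bear on it.

Three compounds have been measured in a functional assay on KBVIN cells (Homo sapiens) for antiproliferative activity, read by sulforhodamine B assay, with a stated time of 3 days; a lower number here means that less compound is needed, a higher number that more compound is needed for the effect:

Compound 1, `CCC1=C(O)c2c(oc(-c3ccc(OC(F)(F)F)cc3)cc2=O)C(CC)(CC)C1=O`, gives 9.95 uM.
Compound 2, `CCC1=C(O)c2c(oc(-c3cccc(C)c3)cc2=O)C(CC)(CC)C1=O`, gives 3.69 uM.
Compound 3, `CCC1=C(O)c2c(oc(-c3cc(OC)c(OC)c(OC)c3)cc2=O)C(CC)(CC)C1=O`, gives 5.6 uM.

All three share the same core and differ only in the aryl group attached to it. Compound 2 carries the lowest of the three numbers in this assay. Its closest neighbour is compound 3, whose number is higher by an amount that stays within the usual scatter of repeated measurements, so the two cannot be told apart with confidence. Compound 1 stands furthest away, with a number that lies beyond the scatter, so compound 2 does need less material than compound 1 for the same effect.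

Compound 4, `CCC1=C(O)c2c(oc(-c3cc(C)c(O)c(C)c3)cc2=O)C(CC)(CC)C1=O`, is the next compound to consider. It differs from compound 2 in one place: 4-hydroxy-3,5-dimethylphenyl in place of 3-methylphenyl on an aromatic carbon.

Among the measured compounds shown here, no pair of measured compounds differs in just this way, so there is no measured step to lean on. Because compound 1 and compound 3 both gave numbers no lower than compound 2, a modest move toward a higher number is expected, though one that stays within the scatter. The step from compound 2 to compound 4 in this assay is estimated as a 1.4-fold higher number from compound 2 to compound 4 (0.13 log units; within the scatter), and compound 4 is expected to give about 5 uM, most likely between 2 uM and 12 uM.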

Compound 4, concentration for half-maximal effect: 8.9 uM
Compound 4: the middle estimate sits 1.8-fold (0.25 log units) below what was measured; low and high end bracket the measured number.
By their numbers in this assay, from the lowest: compounds 2, 3, 4 and 1 (each within the scatter of the next, the first and the last beyond it).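

In this assay, putting 4-hydroxy-3,5-dimethylphenyl in place of 3-methylphenyl on this aromatic carbon gives a 2.4-fold higher number from compound 2 to compound 4 (0.38 log units; beyond the scatter). This is the only step shown between compounds that differ in one place, and it establishes that the aryl group at this position can change the number by more than the usual scatter, though the size of the effect is modest. The entering group differs from the leaving one in several ways at once, since it has a hydroxy group and a different set of methyl groups, and nothing available connects the higher number to any property of the group or explains the change.

Among the compounds shown here, the single step cannot show whether the hydroxy group, the added methyl group or their combination accounts for the shift, and a phenyl ring differing from 3-methylphenyl by only one of these features would be needed to separate them. It also leaves open how this position would respond to an amine or a carboxylic acid on the phenyl ring, or to a longer chain such as ethyl or propyl in place of the methyl group.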